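The compounds below may be only part of what the source reports. "The series", "measured", "known", "first", "only" and "open" are said of these compounds alone.

Compound 1 `Fc1ccc(C2CC(c3ccc(Cl)s3)=NN2c2nc(-c3ccc(Cl)cc3)cs2)cc1` is the starting point here. In an ADME assay on NIH3T3 cells (Mus musculus) for cytotoxicity, read by XTT assay, with a stated time of 24 h (a higher number here means a weaker inhibitor, a lower number a stronger inhibitor), compound 1 gives > 500 ug/mL, which is a limit of the assay and not a number. Compound 2 `Cc1ccc(-c2csc(N3N=C(c4ccc(C)s4)CC3c3ccc(F)cc3)n2)cc1` gives > 500 ug/mL, and this too is a limit. The record so far is therefore (the limit of > 500 ug/mL in this assay, at which 2 of the 2 values shown sit). Among the compounds with values here, neither compound has an exact number yet, and no pair of measured compounds differs by a single change that could guide a prediction.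

The next compound, compound 3 `Fc1ccc(C2CC(c3ccc(Cl)s3)=NN2c2nc(-c3ccccc3)cs2)cc1`, comes from compound 1 through one edit: hydrogen in place of chloro on an aromatic carbon. In words, hydrogen takes the place of chloro on an aromatic carbon, so 4-chlorophenyl becomes phenyl. With no measurement of this change to draw on, no step beyond the usual scatter of this assay is expected, and neither direction is favoured. The estimated change is a number no higher from compound 1 to compound 3 (the limit leaves the size open). This expectation rests on compound 1 at > 500 ug/mL, and another limit is the likeliest result. For compound 3, the expected value is 500 ug/mL, with an estimated range from 300 ug/mL to 1000 ug/mL.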

Compound 3, half-maximal inhibitory concentration: > 500 ug/mL
Compound 3: no number, only a limit; the forecaster's own chance of this, stated with the estimate: 80%; the middle value sits exactly at the limit.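

Compound 1 and compound 3 each give only a limit of the assay and not a number, so no step can be read between them. The compounds shown leave open what exact value any of them has in this assay, and whether hydrogen in place of chloro changes that value at all. The record now reads: the limit of > 500 ug/mL in this assay, at which 3 of the 3 values shown sit.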